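Working notes: chloro in place of hydrogen on compound 1

This account rests on a few compounds, and the source may have more. Where it says the series, first, only, none or still open, it means among the compounds named here.

- compound 1 `CO/N=C1/C(=O)N(CCCCCCC(=O)NO)c2ccccc21` gives 750 nM
- compound 2 `CO/N=C1/C(=O)N(CCCCCCC(=O)NO)c2ccc(F)cc21` gives 970 nM

In a functional assay on NCI-H460 cells (Homo sapiens) for antiproliferative activity, read by sulforhodamine B assay, with a stated time of 48 h (a lower number here means a stronger inhibitor, a higher number a weaker inhibitor), compound 1 gives 750 nM. Among the compounds with values here, the one measured step from it, a 1.3-fold higher number from compound 1 to compound 2 (0.11 log units; within the scatter), leaves compound 1 with no separation from the only other measured compound.

The next compound to be measured is compound 3 `CO/N=C1/C(=O)N(CCCCCCC(=O)NO)c2c(Cl)cccc21`. The change is chloro in place of hydrogen on an aromatic carbon, in words chloro in place of hydrogen on an aromatic carbon, ortho to a fused ring and meta to a fused ring.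

Only the fluoro in place of hydrogen step bears on this change, and it is a limited guide, since it involves a different halogen on a different aromatic carbon. Within the data shown here, no chloro compound has been measured yet, and no change at this carbon. Among the measured compounds shown here, the single halogen step, a 1.3-fold higher number from compound 1 to compound 2 (0.11 log units; within the scatter), stayed small, so no step beyond the scatter is expected in this assay, in either direction. The expected step is a 1.2-fold higher number from compound 1 to compound 3 (0.08 log units; within the scatter). For compound 3 the estimated value is 900 nM, with an estimated range from 350 nM to 2300 nM.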

Compound 3, half-maximal inhibitory concentration: 350 nM
Estimate against measurement, compound 3: 2.6-fold (0.41 log units) above, and the stated range covers the measured number.
By their numbers in this assay, from the lowest: compound 3; then compounds 1 and 2 (each within the scatter of the next).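

In this assay, chloro in place of hydrogen on an aromatic carbon, ortho to a fused ring and meta to a fused ring, gives a 2.1-fold lower number from compound 1 to compound 3 (0.33 log units; beyond the scatter), a modest step and the first in this series beyond the scatter. The earlier step, a 1.3-fold higher number from compound 1 to compound 2 (0.11 log units; within the scatter), stayed within the scatter, but it involved fluoro on a different aromatic carbon, so the two steps differ in both group and place and do not show which of the two matters. No measurement at hand accounts for the lower number at compound 3.

On these data alone, it remains open whether this step belongs to chloro itself or to this carbon: fluoro, methyl or methoxy on the same carbon would test the first, and chloro on the carbon that carries fluoro in compound 2 would test the second. Within the data shown here, also open is whether the step persists on a core with a longer chain in place of the one in compound 1.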